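Aryl amine swap at the weak end of the series

A few compounds are considered here, and "the series" means these few. Any claim that something is new, unique, unknown or untested is made for them only; others in the source may bear on it.

Compound 1 `COc1cc(N2CCN(C(C)=O)CC2)ccc1Nc1ncc(C(F)(F)F)c(N2Cc3cccc(N(C)S(C)(=O)=O)c3C2)n1` carries a methoxy- and acetylpiperazine-bearing aryl group on the shared core; in a functional assay on A549 cells (Homo sapiens) for antiproliferative activity, read by spectrophotometry, with a stated time of 2 days (on this read-out higher numbers stand for weaker inhibition of growth and lower numbers for stronger inhibition of growth), compound 1 gives 3300 nM. Compound 2 `Cc1ccc(Nc2ncc(C(F)(F)F)c(N3Cc4cccc(N(C)S(C)(=O)=O)c4C3)n2)c(Cl)c1` bears 2-chloro-4-methylphenyl on the same nitrogen. In this assay compound 2 reaches only the assay limit, > 30000 nM, so it has no number of its own and sits at the weak end of the set. Compound 3 `Cc1cc(Cl)ccc1Nc1ncc(C(F)(F)F)c(N2Cc3cccc(N(C)S(C)(=O)=O)c3C2)n1` carries 4-chloro-2-methylphenyl instead; in this assay compound 3 gives 25500 nM, and the step of an at least 1.1-fold lower number from compound 2 to compound 3 (0.07 log units; that floor lies within the scatter) lies within the scatter and begins at the limit of > 30000 nM in this assay, at which 1 of the 3 values shown sits.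

Among the compounds with values here, compound 4 `CN(c1cccc2c1CN(c1nc(Nc3ccc(Cl)c(C(F)(F)F)c3)ncc1C(F)(F)F)C2)S(C)(=O)=O` varies the same nitrogen once more. 4-chloro-3-(trifluoromethyl)phenyl in place of 2-chloro-4-methylphenyl on a nitrogen on an aromatic ring The only measured step on this site, an at least 1.1-fold lower number from compound 2 to compound 3 (0.07 log units; that floor lies within the scatter), kept a halogenated phenyl and stayed weak. Compound 1 shows that a quite different aryl can give 3300 nM, but nothing ties that aryl to the trifluoromethyl one. Compound 4 is therefore expected to remain weak, at about 25000 nM, between 8000 nM and 30000 nM, with a fair chance of another limit. The expected step of an at least 1.2-fold lower number from compound 2 to compound 4 (0.07 log units; that floor lies within the scatter) is none beyond the scatter.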

Compound 4, concentration for 50% growth inhibition: 15200 nM
The estimate for compound 4 lay 1.6-fold (0.22 log units) above the measured number, and the stated range covers the measured number.
By their numbers in this assay, from the lowest: compound 1; then compounds 4 and 3 (each within the scatter of the next). At a limit, above all of these: compound 2.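

On this nitrogen, 4-chloro-3-(trifluoromethyl)phenyl gives a measured value in this assay, and the change reads as an at least 1.9-fold lower number from compound 2 to compound 4 (0.29 log units; that floor lies within the scatter), and as a 1.7-fold lower number from compound 3 to compound 4 (0.22 log units; within the scatter). Neither step separates these aryl groups, so exchanging the methyl for a trifluoromethyl group and moving the chlorine, as in these three halogenated phenyl groups, produces no change beyond the scatter in this read-out. For compound 2 the comparison has only a floor, and its true size stays unknown: the limit of > 30000 nM in this assay, at which 1 of the 4 values shown sits.

On these data alone, it remains open whether the methoxy group, the acetylpiperazine or the two together account for compound 1 giving 3300 nM. Also open, as far as these compounds go, is how a phenyl group carrying a morpholine or a free piperazine amine would read at this nitrogen.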